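One Arm Swapped on the Sulfur-Linked Chain

The compounds below may be only part of what the source reports. "The series", "measured", "known", "first", "only" and "open" are said of these compounds alone.

Compound 2 `COc1cc(-c2nnc(SCc3ccc(C)cc3)n2-c2ccc(N(C)C)cc2)cc(OC)c1OC` has been tested in a functional assay on HepG2 cells (Homo sapiens) for inhibition, read by MTT assay, with a stated time of 48 h (a higher number here means a weaker inhibitor, a lower number a stronger inhibitor), where compound 2 reaches the limit > 60000 nM, which is a boundary of the assay rather than a number. Its neighbour compound 1 `COc1ccc(-n2c(SCc3ccc(C)cc3)nnc2-c2cc(OC)c(OC)c(OC)c2)cc1` differs in carrying methoxy where compound 2 carries dimethylamino, and in this assay compound 1 gives 31600 nM. Going by the values given here, the single measured step, an at least 1.8-fold higher number from compound 1 to compound 2 (0.27 log units; that floor lies within the scatter), is the only comparison available, and its floor comes from the limit of > 60000 nM in this assay, at which 1 of the 2 values shown sits.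

Compound 3 `COc1ccc(NC(=O)CSc2nnc(-c3cc(OC)c(OC)c(OC)c3)n2-c2ccc(N(C)C)cc2)cc1` is not yet measured. Its change from compound 2 is (4-methoxyphenyl)carbamoyl in place of 4-methylphenyl on a saturated chain carbon bound to a sulfur. Among the compounds with values here, no measured step touches the sulfur-linked chain; the one step concerns the dimethylamino-for-methoxy swap and does not bear on this change. The expectation therefore rests on compound 2 alone, and the step is estimated as an at least 1.2-fold lower number from compound 2 to compound 3 (0.07 log units; that floor lies within the scatter), which is no movement beyond the scatter. Compound 3 is expected to give about 50000 nM, within 15000 nM to 150000 nM, with a real chance that this assay again reports only a limit.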

Compound 3, half-maximal inhibitory concentration: > 60000 nM
Compound 3: no number, only a limit (the forecaster's own chance of this, stated with the estimate: 50%); middle value at least 1.2-fold (0.07 log units) away from the limit.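

In this assay compound 3 reaches > 60000 nM as a limit of the assay, not a number. Compound 2 also stands at a limit, so no step between compound 2 and compound 3 can be read: the limit of > 60000 nM in this assay, at which 2 of the 3 values shown sit.

The compounds shown leave open whether swapping 4-methylphenyl for (4-methoxyphenyl)carbamoyl on the sulfur-linked chain changes inhibition at all.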